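Added methyl on the chain carbon of compound 1

A few compounds are considered here, and "the series" means these few. Any claim that something is new, unique, unknown or untested is made for them only; others in the source may bear on it.

Measured in an ADME assay on CHO cells (Cricetulus griseus) for cytotoxicity, read by LDH release; a higher number here means a weaker inhibitor, a lower number a stronger inhibitor:
- compound 1 `CC(Oc1ccc(Cl)cc1Cl)C(=O)NC(C)c1ccc(F)cc1`: > 100000 nM
- compound 2 `CC(Oc1ccc(Cl)cc1Cl)C(=O)N[C@H](C)c1ccc(F)cc1`: 97000 nM

Compound 1 stands at > 100000 nM, which is a limit of this assay and not a number. Compound 3 `CC(Oc1ccc(Cl)cc1Cl)C(=O)NC(C)(C)c1ccc(F)cc1` is not yet measured. It differs from compound 1 by methyl in place of hydrogen on a saturated chain carbon bound to an amide-type nitrogen, an aromatic carbon and a saturated chain carbon, with methyl in place of hydrogen on a saturated chain carbon bound to an amide-type nitrogen, an aromatic carbon and a saturated chain carbon. Going by the values given here, the only measured step touching this carbon is an at least 1.0-fold lower number from compound 1 to compound 2 (0.01 log units; that floor lies within the scatter), and it concerns drawn configuration only. Among the compounds with values here, no measured step adds a group there, so this is weak guidance, and no shift beyond the scatter is expected in this assay. The expected change is a number no higher from compound 1 to compound 3 (the limit leaves the size open). For compound 3 the estimated value is 100000 nM, with an expected range of 45000 nM to 220000 nM.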

Compound 3, half-maximal inhibitory concentration: > 100000 nM
Compound 3: a limit, no number; the forecaster's own chance of this, stated with the estimate: 60%; the middle value lies on the limit itself.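

In this assay compound 3 gives > 100000 nM, which is a limit and not a number. Going by these compounds alone, compound 1 also stands at a limit, so no step from compound 1 to compound 3 can be read. The compounds shown leave open whether methyl in place of hydrogen on this saturated chain carbon changes the number in this assay.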